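The source may hold more compounds than are shown below. What is called first, only, known or untested is meant among the compounds shown, and "the series" means these compounds.

Within the data shown here, compound 2 `COc1cc2cc(Oc3ccc(NC(=O)Nc4ccc(C(F)(F)F)cc4)cc3)c(C)nc2cc1OC` gives the lower of the two numbers recorded in a functional assay on SR cells (Homo sapiens) for inhibition, read by sulforhodamine B assay, with a stated time of 48 h, tested at 10 uM (on this read-out higher numbers stand for a weaker effect at the one concentration tested and lower numbers for a stronger effect), at 59.6%; compound 1 `COc1cc2cc(Oc3ccc(NC(=O)Nc4ccc(C)cc4)cc3)c(C)nc2cc1OC` gives 83.1%, and the only measured step, a number 23.5 percentage points lower from compound 1 to compound 2 (beyond the scatter), is a change of group rather than of position. Compound 3 `COc1cc2cc(Oc3ccc(NC(=O)Nc4cccc(C(F)(F)F)c4)cc3)c(C)nc2cc1OC` differs from compound 2 by 3-(trifluoromethyl)phenyl in place of 4-(trifluoromethyl)phenyl on an amide-type nitrogen. Among the measured compounds shown here, no measured step bears on a shift of the trifluoromethyl group, so compound 3 is expected to give 62%, within 40% to 85%, in this assay. The estimated step of a number 2.4 percentage points higher from compound 2 to compound 3 (within the scatter) is expected to lie within the scatter, in no firm direction.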

Compound 3, a percentage reported as activity, at one concentration (the size of the read-out at that concentration, not a potency): -6.62%
Beside the measured number, compound 3's estimate is 68.6 percentage points above it, outside the stated range (below it).
By their numbers in this assay, from the lowest: compound 3; then compound 2; then compound 1.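

In this assay, the shift to 3-(trifluoromethyl)phenyl on the amide-type nitrogen gives a number 66.2 percentage points lower from compound 2 to compound 3 (beyond the scatter), so where the trifluoromethyl group stands on this ring matters here, not only which group is present. Measured against the 4-methylphenyl of the first compound, the same group gives a number 89.7 percentage points lower from compound 1 to compound 3 (beyond the scatter). No evidence at hand accounts for this shift. As far as these compounds go, whether 3-methylphenyl would follow compound 3 or compound 1 remains open, and so does whether a nitrile or an amine in the place of the trifluoromethyl group would keep the effect.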